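Sulfonamide series: methoxy for ethyl on the phenyl

This account rests on a few compounds, and the source may have more. Where it says the series, first, only, none or still open, it means among the compounds named here.

Three members of the series are measured. Compound 1 `O=S(=O)(Nc1ccc(-c2nc3ccccc3o2)cc1)c1cccs1` carries thiophen-2-yl on the sulfonyl sulfur, compound 2 `O=S(=O)(Nc1ccc(-c2nc3ccccc3o2)cc1)c1ccccc1O` carries 2-hydroxyphenyl there, and compound 3 `CCc1ccc(S(=O)(=O)Nc2ccc(-c3nc4ccccc4o3)cc2)cc1` carries 4-ethylphenyl. In an assay on cells for inhibition of HSP60/HSP10 (Homo sapiens), with a stated time of 60 min (a higher number here means a weaker inhibitor, a lower number a stronger inhibitor), compound 1 gives 63000 nM. Compound 2 gives > 100000 nM, which is a limit of this assay and not a number. Compound 3 gives > 100000 nM, again a limit of this assay. So compound 3 stands at the ceiling of what this assay reports, as the limit of > 100000 nM in this assay, at which 2 of the 3 values shown sit, shows. The steps of an at least 1.5-fold higher number from compound 1 to compound 2 (0.20 log units; that floor lies within the scatter) and an at least 1.5-fold higher number from compound 1 to compound 3 (0.20 log units; that floor lies within the scatter) are therefore only floors, and the step that the two limits leave unreadable from compound 2 to compound 3 cannot be sized at all.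

Compound 4 `COc1ccc(S(=O)(=O)Nc2ccc(-c3nc4ccccc4o3)cc2)cc1` differs from compound 3 by methoxy in place of ethyl on an aromatic carbon. For the measured compounds named here, none of the measured steps exchanges one substituent for another on the same phenyl; the two floors and the unreadable step all swap the entire group on the sulfonyl sulfur, so they set no size for this change, and no step beyond the scatter is expected in this assay. Compound 4 is expected to stay at or near the ceiling, with a step of a number no higher from compound 3 to compound 4 (the limit leaves the size open) that is not readable against a limit. Compound 4 is estimated at 100000 nM, within 40000 nM to 300000 nM, most probably reported as a limit once more.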

Compound 4, half-maximal inhibitory concentration: > 100000 nM
Compound 4 was reported as a limit; the forecaster's own chance of this, stated with the estimate: 70%; the middle value sits exactly at the limit.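

With methoxy in place of ethyl, para to a large group, compound 4 joins the compounds at the ceiling of this assay, so a hydrogen-bond acceptor on this aromatic carbon gives no reading under the limit: the limit of > 100000 nM in this assay, at which 3 of the 4 values shown sit. The steps to compound 4 from compound 2 and from compound 3 cannot be read, as both ends of each are limits, and the exchange of ethyl for methoxy therefore has no size. The one step that can be read, an at least 1.5-fold higher number from compound 1 to compound 4 (0.20 log units; that floor lies within the scatter), is only a floor, so compound 4 is not shown to differ from compound 1 beyond the scatter.

As far as these compounds go, whether any group on this phenyl carbon can bring a reading under the limit stays open; an amine, a carboxylic acid or a longer chain there would be the next groups to read. Also open, from the compounds shown here alone, is whether compound 1, at 63000 nM, truly stands apart from the phenyl members, as all of its steps to them are floors within the scatter.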